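The compounds below may be only part of what the source reports. "The series", "measured", "known", "first", "only" and "open" are said of these compounds alone.

Measured so far:
compound 1 `CC(C)(C)/N=c1\c(O)c(O)\c1=N/Cc1cccc(F)c1`: 2400 nM
compound 2 `CC(C)(C)/N=c1\c(O)c(O)\c1=N/Cc1ccccc1`: 3400 nM
compound 3 `CCC(C)(C)/N=c1\c(O)c(O)\c1=N/Cc1ccc(C)c(C)c1`: > 30000 nM

In a functional assay for inhibition, with Rattus norvegicus as the target (on this read-out lower numbers stand for stronger inhibition and higher numbers for weaker inhibition), compound 1 gives 2400 nM and compound 2 gives 3400 nM; the two numbers sit within the scatter of each other, as the step of a 1.4-fold higher number from compound 1 to compound 2 (0.15 log units; within the scatter) shows. The value of compound 3 is a limit of the assay (the limit of > 30000 nM in this assay, at which 1 of the 3 values shown sits), not a number. Compound 4 `CC(C)(C)/N=c1\c(O)c(O)\c1=N/Cc1cc(F)ccc1F` differs from compound 1 by fluoro in place of hydrogen on an aromatic carbon. Among the compounds with values here, the only measured step that bears on this change is the removal of the fluoro group, a 1.4-fold higher number from compound 1 to compound 2 (0.15 log units; within the scatter), which stayed within the scatter. A second fluoro group is therefore expected to move the number little in this assay. Compound 4 is expected to give 2000 nM (range 700 nM to 6000 nM), a step of a 1.2-fold lower number from compound 1 to compound 4 (0.08 log units; within the scatter) that is expected to stay within the scatter.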

Compound 4, half-maximal inhibitory concentration: 3900 nM
For compound 4 the middle estimate is 2.0-fold (0.29 log units) below the measured one; low and high end bracket the measured number.
By their numbers in this assay, from the lowest: compounds 1, 2 and 4 (each within the scatter of the next). At a limit, above all of these: compound 3.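

Fluoro in place of hydrogen on this aromatic carbon, ortho to a large group and para to a fluoro group, is tolerated in this assay: the step is a 1.6-fold higher number from compound 1 to compound 4 (0.21 log units; within the scatter). Within the data shown here, the series now holds a within-scatter fluoro change at this position as well as the one separating compound 1 from compound 2. Nothing measured here accounts for this outcome.

Open, from the compounds shown here alone, is whether a group larger than fluoro at this position, such as methoxy, an amine or a carboxylic acid, would also stay within the scatter of compound 1.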